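This account rests on a few compounds, and the source may have more. Where it says the series, first, only, none or still open, it means among the compounds named here.

Compound 3, `COc1ccc(-c2c(Cl)c(=O)c3c(OC)cc(OC)cc3n2S(=O)(=O)c2ccc(OC)cc2)cc1`, carries a chloro group and a (4-methoxyphenyl)sulfonyl group on the shared core that compounds 1 and 2 also bear. In a functional assay on SEM cells (Homo sapiens) for antiproliferative activity, with a stated time of 72 h (a higher number here means that more compound is needed for the effect, a lower number that less compound is needed), the record for compound 3 reads "not determined" (no result reported), so no number places it among the others. Compound 1, `COc1ccc(-c2cc(=O)c3c(OC)cc(OC)cc3[nH]2)cc1`, gives in this assay a value that is a limit of the assay, > 31100 nM. Compound 2, `COc1ccc(-c2cc(=O)c3c(OC)cc(OC)cc3n2Cc2ccccc2)cc1`, likewise gives only a limit in this assay, > 17300 nM. For the measured compounds named here, the one measured step, a step that the two limits leave unreadable from compound 1 to compound 2, therefore cannot be sized; what the two compounds show is summed up by the limit of > 17300 nM in this assay, at which 1 of the 3 values shown sits, and (the limit of > 31100 nM in this assay, at which 1 of the 3 values shown sits).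

Compound 4, `COc1ccc(-c2c(Br)c(=O)c3c(OC)cc(OC)cc3n2S(=O)(=O)c2ccc(OC)cc2)cc1`, differs from compound 3 by bromo in place of chloro on an aromatic carbon. Going by the values given here, no measured step speaks directly to an exchange of one halogen for another at this place, and neither of the two limits bears on it, since both belong to compounds without the sulfonyl group and without a halogen. Among the compounds with values here, with nothing to lean on beyond the two limits, no direction and no size of step in this assay can be drawn from the data, and a limit for compound 4 is a real possibility. On this basis compound 4 is expected to give about 5000 nM in this assay, estimated within a range from 200 nM to 50000 nM.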

Compound 4, half-maximal effective concentration: 1900 nM
Compound 4: middle estimate off by 2.6-fold (0.42 log units), on the high side; measured number inside the range.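

Compound 3 has no number in this assay, so no step from it to compound 4 can be read, and nothing shown bears on the result for compound 4. The compounds shown leave open whether bromo in place of chloro on an aromatic carbon changes the value in this assay at all.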